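Quinoline for pyridine on the amide carbonyl of compound 3

The source may report more compounds than this note shows. Statements on the series, on what has been measured and on what is new or still open speak of the compounds shown alone.

Measured so far:
compound 1, `COc1ccc(NC(=O)NS(=O)(=O)N2CCC(CCNC(=O)c3cc(Cl)ccc3OC)CC2)cc1`, 27%
compound 2, `O=C(NC[C@@H]1C[C@@H]2C=C[C@@H]1C2)NS(=O)(=O)N1CCC(CCNC(=O)C(F)(F)F)CC1`, 22%
compound 3, `COc1ccc(C(=O)NCCC2CCN(S(=O)(=O)NC(=O)NC[C@@H]3C[C@@H]4C=C[C@@H]3C4)CC2)cn1`, 11%

In a functional assay on the whole organism (blood) with Rattus norvegicus as the target, with stated times of 24 h and 1 h, at a dose of 5 mg/kg by the intraperitoneal route (a higher number here means a stronger effect of the compound at the dose given, a lower number a weaker effect), compound 3 gives 11%, the lowest of the three numbers. Compound 2 gives 22%, and compound 1 gives 27%; these two lie within the scatter of each other. Among the measured compounds shown here, the only step that changes one place is a number 11 percentage points lower from compound 2 to compound 3 (beyond the scatter), a modest drop on going from a trifluoromethyl to an aromatic ring on the carbonyl carbon.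

Compound 4, `COc1ccc2nccc(C(=O)NCCC3CCN(S(=O)(=O)NC(=O)NC[C@@H]4C[C@@H]5C=C[C@@H]4C5)CC3)c2c1`, differs from compound 3 by 6-methoxyquinolin-4-yl in place of 6-methoxypyridin-3-yl on a carbonyl carbon. For the measured compounds named here, no measured step exchanges one aromatic ring for a larger bicyclic one on that carbonyl, so nothing bears on it directly; compound 1 shows only that an aromatic group on the amide carbonyl can sit at the higher end of this small set. The expected step in this assay is therefore a number 6 percentage points higher from compound 3 to compound 4 (within the scatter), small and of uncertain direction, possibly within the scatter. Compound 4 is estimated at 17%, in the range 5% to 30%.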

Compound 4, a percentage reported as activity, at one dose (the size of the read-out at that dose, not a potency): 10%
For compound 4 the middle estimate is 7 percentage points above the measured one, and the stated range covers the measured number.
By their numbers in this assay, from the lowest: compounds 4 and 3 (each within the scatter of the next); then compounds 2 and 1 (each within the scatter of the next).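

The step of a number 1 percentage points lower from compound 3 to compound 4 (within the scatter) in this assay shows that, at this place on a carbonyl carbon whose other neighbour is an amide-type nitrogen, adding a six-membered aromatic ring of carbon only to the pyridine gives no readable change. The step of a number 12 percentage points lower from compound 2 to compound 4 (beyond the scatter) stands with a number 11 percentage points lower from compound 2 to compound 3 (beyond the scatter) as a second case, so the difference from trifluoromethyl no longer rests on compound 3 alone. No measurement at hand accounts for either step.

Open, as far as these compounds go, is whether a small non-aromatic group on the carbonyl, such as methyl or cyclohexyl, reads nearer to trifluoromethyl or to the two aromatic groups. Also open, from the compounds shown here alone, is how an amine or a carboxylic acid in place of the methoxy group would read on either aromatic ring.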